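Swapping a benzyl methyl for fluorine in a urea series

The compounds below may be only part of what the source reports. "The series", "measured", "known", "first", "only" and "open" are said of these compounds alone.

Three compounds share one core and differ only in the group carried on a saturated chain carbon bound to an oxygen on an aromatic ring. In a functional assay on MNK45 cells (Homo sapiens) for inhibition, read by MTT assay, with a stated time of 48 h (on this read-out lower numbers stand for stronger inhibition and higher numbers for weaker inhibition), compound 1 `Cc1ccc(NC(=O)NC(=O)c2ccc(OCc3cccc(Cl)c3)cc2)cc1-c1nc2ccccc2[nH]1` gives 28000 nM, compound 2 `Cc1ccc(NC(=O)NC(=O)c2ccc(OCc3ccccc3F)cc2)cc1-c1nc2ccccc2[nH]1` gives 1830 nM, and compound 3 `Cc1ccc(COc2ccc(C(=O)NC(=O)Nc3ccc(C)c(-c4nc5ccccc5[nH]4)c3)cc2)cc1` gives 6360 nM, which places compound 3 between the other two: a 4.4-fold lower number from compound 1 to compound 3 (0.64 log units; beyond the scatter), while a 3.5-fold higher number from compound 2 to compound 3 (0.54 log units; beyond the scatter) and a 15-fold lower number from compound 1 to compound 2 (1.18 log units; beyond the scatter). Compound 4 `Cc1ccc(NC(=O)NC(=O)c2ccc(OCc3ccc(F)cc3)cc2)cc1-c1nc2ccccc2[nH]1` is not yet measured; its change from compound 3 is fluoro in place of methyl on an aromatic carbon. Among the compounds with values here, no measured step trades methyl for fluoro at one place, so the three steps only show that this position matters beyond the scatter. A modest step is therefore expected, a 1.8-fold lower number from compound 3 to compound 4 (0.26 log units; within the scatter), toward a lower number, and compound 4 is estimated at 3500 nM, within 1200 nM to 10000 nM.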

Compound 4, half-maximal inhibitory concentration: 240 nM
Compound 4: the middle estimate sits 15-fold (1.16 log units) above what was measured, outside the stated range (below it).
By their numbers in this assay, from the lowest: compound 4; then compound 2; then compound 3; then compound 1.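

In this assay, trading methyl for fluoro at this one place, para to a large group, gives a 27-fold lower number from compound 3 to compound 4 (1.42 log units; beyond the scatter), so a single-atom change here can shift the number sharply. The place of the fluorine counts too: 4-fluorophenyl in place of 2-fluorophenyl gives a 7.6-fold lower number from compound 2 to compound 4 (0.88 log units; beyond the scatter), and 4-fluorophenyl in place of 3-chlorophenyl gives a 120-fold lower number from compound 1 to compound 4 (2.07 log units; beyond the scatter). No measurement at hand explains these gaps. Still open, from the compounds shown here alone, is whether 4-chlorophenyl, 4-methoxyphenyl or plain phenyl would match 4-fluorophenyl.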